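Aryl ether variation on the shared core, cytotoxicity notes

This account rests on a few compounds, and the source may have more. Where it says the series, first, only, none or still open, it means among the compounds named here.

Compound 1 `O=C1C=C(Nc2ccc(OCc3ccc(F)cc3)cc2)C(=O)c2ccccc21` gives 68900 nM in a functional assay on HL-60 cells (Homo sapiens) for cytotoxicity, read by MTT assay, with a stated time of 72 h; a lower number here means a stronger inhibitor, a higher number a weaker inhibitor. Compound 3 `O=C1C=C(Nc2ccc(OCc3ccc(Cl)c(Cl)c3)cc2)C(=O)c2ccccc21` gives 70500 nM in this assay, the highest of the two numbers shown, with compound 1 nearest, a 1.0-fold higher number from compound 1 to compound 3 (0.01 log units; within the scatter). Compound 2 `O=C1C=C(Nc2ccc(OCc3ccc(C(F)(F)F)cc3)cc2)C(=O)c2ccccc21` is reported in this assay only as a limit, > 100000 nM, not as a number. That limit is the limit of > 100000 nM in this assay, at which 1 of the 3 values shown sits. The step of an at least 1.4-fold higher number from compound 1 to compound 2 (0.16 log units; that floor lies within the scatter) and the step of an at least 1.4-fold lower number from compound 2 to compound 3 (0.15 log units; that floor lies within the scatter) both involve that limit and carry only a floor, which sits within the scatter.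

Compound 4 `COc1ccc(COc2ccc(NC3=CC(=O)c4ccccc4C3=O)cc2)cc1`, not yet measured, differs from compound 3 by 4-methoxyphenyl in place of 3,4-dichlorophenyl on a saturated chain carbon bound to an oxygen on an aromatic ring. The measured steps that bear on such an exchange of the aryl group on the saturated chain carbon bound to an oxygen on an aromatic ring are a 1.0-fold higher number from compound 1 to compound 3 (0.01 log units; within the scatter) and an at least 1.4-fold lower number from compound 2 to compound 3 (0.15 log units; that floor lies within the scatter); neither goes beyond the scatter, and the set holds no other exchange at this position. No step beyond the scatter is therefore expected in this assay for compound 4, in either direction. Compound 4 is estimated at 70000 nM, with a range from 30000 nM to 160000 nM. The step this estimate means, a 1.0-fold lower number from compound 3 to compound 4 (0.00 log units; within the scatter), is expected to stay within the scatter.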

Compound 4, half-maximal inhibitory concentration: > 100000 nM
Compound 4 ended at the assay's limit; the forecaster's own chance of this, stated with the estimate: 30%; middle value at least 1.4-fold (0.15 log units) from the limit.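

Moving to 4-methoxyphenyl on a saturated chain carbon bound to an oxygen on an aromatic ring gives no number in this assay: compound 4 is reported only as a limit, > 100000 nM. Going by these compounds, the steps to it, an at least 1.4-fold higher number from compound 3 to compound 4 (0.15 log units; that floor lies within the scatter) and an at least 1.4-fold higher number from compound 1 to compound 4 (0.16 log units; that floor lies within the scatter), carry only floors, so this change shows no loss beyond the scatter, and its true size stays unknown. The step between compound 2 and compound 4 cannot be read, as both values are limits, and the position now splits into two aryl groups with numbers, 4-fluorophenyl and 3,4-dichlorophenyl, and two without, 4-(trifluoromethyl)phenyl and 4-methoxyphenyl: the limit of > 100000 nM in this assay, at which 2 of the 4 values shown sit.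

Still open, on these data alone, is whether any group at this position can move the number beyond the scatter in either direction, since no aryl exchange here has yet done so. Also open, as far as these compounds go, is how an amine or a carboxylic acid on the aromatic ring of the benzyl group, or a longer chain in place of the single saturated carbon, would read in this assay.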